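This account rests on a few compounds, and the source may have more. Where it says the series, first, only, none or still open, it means among the compounds named here.

Compound 2 `COc1cc(O)c(C(=O)/C=C/c2ccccc2OC)c(OC)c1` stands highest of the three measured compounds in a functional assay on HCT-116 cells (Homo sapiens), read by fluorescence and BrdU incorporation, with a stated time of 48 h, tested at 10 uM; a higher number here means a weaker effect of the compound at the concentration tested, a lower number a stronger effect. In this assay compound 2 gives 42%. Compound 1 `COc1cc(OC)c(C(=O)/C=C/c2ccccc2SC)c(OC)c1` lies nearest to it, and in this assay compound 1 gives 25%. Compound 3 `COc1cc(OC)c(C(=O)/C=C/c2ccc(F)cc2)c(OC)c1` lies furthest away, and in this assay compound 3 gives 23%. Among the compounds with values here, the only single-point step among the measured compounds, a number 2 percentage points lower from compound 1 to compound 3 (within the scatter), puts 4-fluorophenyl in place of 2-(methylsulfanyl)phenyl on the double-bonded chain carbon and leaves the number essentially where it was.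

Compound 4 `COc1cc(O)c(C(=O)/C=C/c2ccccc2SC)c(OC)c1` is the compound now considered. It differs from compound 2 in one place: methylsulfanyl in place of methoxy on an aromatic carbon. Within the data shown here, no measured step mirrors this exchange. Among the measured compounds shown here, compound 1 carries a methylsulfanyl group as well, but it also differs from compound 2 in a group on the shared core, so its two values show only that the methylsulfanyl compound sits lower while the two changes cannot be separated. The step from compound 1 to compound 3 does not bear on the change either. The expected step is therefore a number 7 percentage points lower from compound 2 to compound 4 (within the scatter), a modest lowering that rests on little. Compound 4 is accordingly estimated at 35%, within a range from 20% to 50%.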

Compound 4, a percentage reported as activity, at one concentration (the size of the read-out at that concentration, not a potency): 52%
Compound 4: the middle estimate sits 17 percentage points below what was measured; measured number outside the range, above it.
By their numbers in this assay, from the lowest: compounds 3 and 1 (each within the scatter of the next); then compounds 2 and 4 (each within the scatter of the next).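

In this assay, methylsulfanyl in place of methoxy on an aromatic carbon, ortho to a large group, gives a number 10 percentage points higher from compound 2 to compound 4 (within the scatter) and so cannot be told apart from the usual variation between repeated measurements; methoxy and methylsulfanyl read alike at this position in this pair. Within the data shown here, the other single change, hydrogen in place of methyl on an oxygen on an aromatic ring, gives a number 27 percentage points higher from compound 1 to compound 4 (beyond the scatter) with the methylsulfanyl group held fixed, and this is the first clear single-place reading of that oxygen on the shared core, with the methyl-bearing compound showing the stronger effect at the concentration tested. Nothing shown here explains why either step has the size it has.

The compounds shown leave open whether the change from methyl to hydrogen on that oxygen has a similar size when methoxy or 4-fluorophenyl replaces the methylsulfanyl-bearing part. They also leave open how an ethyl group on that oxygen, or an amine or a chlorine on the aromatic carbon that carries methylsulfanyl, would read in this assay.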